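Halophenyl variation on the aromatic nitrogen: toward compound 4

This account rests on a few compounds, and the source may have more. Where it says the series, first, only, none or still open, it means among the compounds named here.

The series shares one core, seen in compound 1 `O=c1[nH]cc(S(=O)(=O)Nc2cccc(-c3cn(-c4ccccc4F)nn3)c2)c(=O)[nH]1`, with a substituted phenyl on an aromatic nitrogen. In a functional assay on A549 cells (Homo sapiens) for antiproliferative activity, read by MTT assay, with a stated time of 24 h (on this read-out higher numbers stand for weaker inhibition and lower numbers for stronger inhibition), compound 1 reaches only the assay limit, > 20000 nM. Compound 2 `O=c1[nH]cc(S(=O)(=O)Nc2cccc(-c3cn(-c4cccc(F)c4)nn3)c2)c(=O)[nH]1`, carrying 3-fluorophenyl, gives 7200 nM in this assay. Compound 3 `O=c1[nH]cc(S(=O)(=O)Nc2cccc(-c3cn(-c4ccc(F)cc4)nn3)c2)c(=O)[nH]1`, carrying 4-fluorophenyl, again sits at the assay limit, > 20000 nM, in this assay. Compound 3 thus stands at the weak end of the numbers shown, where the limit of > 20000 nM in this assay, at which 2 of the 3 values shown sit, applies. Compound 4 `O=c1[nH]cc(S(=O)(=O)Nc2cccc(-c3cn(-c4ccccc4Cl)nn3)c2)c(=O)[nH]1` differs by 2-chlorophenyl in place of 4-fluorophenyl on an aromatic nitrogen. Going by the values given here, the steps that bear on it are an at least 2.7-fold lower number from compound 1 to compound 2 (0.44 log units; beyond the scatter) and an at least 2.7-fold higher number from compound 2 to compound 3 (0.44 log units; beyond the scatter), while a step that the two limits leave unreadable from compound 1 to compound 3 stays unreadable. Compound 4 is therefore expected to give 20000 nM, between 8000 nM and 50000 nM, most likely again as a limit only. The step of a number no higher from compound 3 to compound 4 (the limit leaves the size open) is expected to be none beyond the scatter.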

Compound 4, half-maximal inhibitory concentration: 2730 nM
Estimate against measurement, compound 4: 7.3-fold (0.86 log units) above; the measured number lies below the stated range.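

Chloro in place of fluoro on an aromatic carbon gives an at least 7.3-fold lower number from compound 1 to compound 4 (0.86 log units; beyond the scatter) and so shows that the halogen, and not only its ring position, decides the result here. 2-chlorophenyl also gives an at least 7.3-fold lower number from compound 3 to compound 4 (0.86 log units; beyond the scatter) and a 2.6-fold lower number from compound 2 to compound 4 (0.42 log units; beyond the scatter) and thereby replaces 3-fluorophenyl as the best group shown. On these data alone, the steps from compound 1 and compound 3 stay open-ended in size: the limit of > 20000 nM in this assay, at which 2 of the 4 values shown sit.

Still open, as far as these compounds go, is whether 3-chlorophenyl and 4-chlorophenyl would follow the order seen with fluoro. Also open, from the compounds shown here alone, is whether 2-bromophenyl or 2-methoxyphenyl would keep the gain seen with 2-chlorophenyl.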